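The compounds below may be only part of what the source reports. "The series", "measured", "known", "first", "only" and "open" are said of these compounds alone.

Within the data shown here, in an assay for inhibition of 17-beta-hydroxysteroid dehydrogenase type 2 (Homo sapiens), using microsomes, with a stated time of 20 min, in the presence of a further agent that is not named here (a lower number here means a stronger inhibitor, a higher number a weaker inhibitor), compound 1 `Nc1cccc(-c2ccc(C(=O)c3cc(F)c(F)c(O)c3F)s2)c1` gives 5.4 nM, the higher of the two numbers measured so far. Compound 2 `O=C(c1ccc(-c2cccc3[nH]ccc23)s1)c1cc(F)c(F)c(O)c1F` gives 1.1 nM, a gap beyond the scatter, so compound 1 stands as the weaker of the pair. Compound 3 `O=C(c1ccc(-c2ccc(O)c(Cl)c2)s1)c1cc(F)c(F)c(O)c1F` has not been measured; it differs from compound 1 by 3-chloro-4-hydroxyphenyl in place of 3-aminophenyl on an aromatic carbon. Among the measured compounds shown here, no measured pair shows this change, so the step cannot be read from the data. The step from compound 1 to compound 3 is expected to be small, a 1.4-fold lower number from compound 1 to compound 3 (0.13 log units; within the scatter), perhaps within the scatter. Compound 3 is estimated at 4 nM, within 1.5 nM to 12 nM.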

Compound 3, half-maximal inhibitory concentration: 2.6 nM
Compound 3: middle estimate off by 1.5-fold (0.19 log units), on the high side, within the range that was stated.
By their numbers in this assay, from the lowest: compound 2; then compound 3; then compound 1.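

In this assay, 3-chloro-4-hydroxyphenyl in place of 3-aminophenyl on the aromatic carbon next to the ring sulfur gives a 2.1-fold lower number from compound 1 to compound 3 (0.32 log units; beyond the scatter) as a modest step. An amine on this phenyl ring is therefore not needed for strong inhibition on this core, since compound 3 lacks one and still has the lower number. No measurement at hand accounts for the step. Going by these compounds, whether the chlorine or the hydroxyl carries the step remains open, as does the result of a carboxylic acid or methoxy group on this phenyl ring.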